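Chloro removal in the diaryl urea series

The compounds below may be only part of what the source reports. "The series", "measured", "known", "first", "only" and "open" are said of these compounds alone.

Three compounds of the shared core have numbers in an ADME assay on WI-38 cells (Homo sapiens) for cytotoxicity, read by MTT assay, with a stated time of 72 h; on this read-out higher numbers stand for weaker inhibition and lower numbers for stronger inhibition. Compound 1 `Cn1ncnc1-c1cc(Oc2ccc(NC(=O)Nc3cccc(C(F)(F)F)c3)cc2F)ccn1` gives 22400 nM, compound 2 `Cn1cnnc1-c1cc(Oc2ccc(NC(=O)Nc3cccc(C(F)(F)F)c3)cc2F)ccn1` gives 12600 nM, and compound 3 `CN(C)CCn1cnnc1-c1cc(Oc2ccc(NC(=O)Nc3ccc(Cl)c(C(F)(F)F)c3)cc2F)ccn1` gives 3760 nM. Among the measured compounds shown here, the only single-point step recorded is a 1.8-fold lower number from compound 1 to compound 2 (0.25 log units; within the scatter). Compound 3 stands lowest of the three numbers, beyond the scatter from both compound 2 and compound 1.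

Compound 4 `CN(C)CCn1cnnc1-c1cc(Oc2ccc(NC(=O)Nc3cccc(C(F)(F)F)c3)cc2F)ccn1` is reached from compound 3 by hydrogen in place of chloro on an aromatic carbon. For the measured compounds named here, no measured step isolates this change: compound 2 and compound 3 differ at the chloro and at the triazole substituent together, so the values of compound 2 and compound 3 show only their combined effect. The recorded step bears on a different site and was within the scatter.

Given that the number of compound 3 stands furthest below compound 2 in this assay, compound 4 is expected to move back toward compound 2, with an estimated step of a 1.6-fold higher number from compound 3 to compound 4 (0.20 log units; within the scatter) in this assay. Compound 4 is therefore estimated at 6000 nM, in the range 2500 nM to 15000 nM.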

Compound 4, half-maximal inhibitory concentration: 11200 nM
Estimate against measurement, compound 4: 1.9-fold (0.27 log units) below, within the range that was stated.
By their numbers in this assay, from the lowest: compound 3; then compounds 4, 2 and 1 (each within the scatter of the next).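

In this assay the chloro of the 4-chloro-3-(trifluoromethyl)phenyl group now has a reading of its own: hydrogen in its place gives a 3.0-fold higher number from compound 3 to compound 4 (0.47 log units; beyond the scatter) and so a modest but real loss of cytotoxic effect at this position. The change at the other site does not show the same: (dimethylamino)methyl on the chain gives a 1.1-fold lower number from compound 2 to compound 4 (0.05 log units; within the scatter) and the full triazolyl exchange gives a 2.0-fold lower number from compound 1 to compound 4 (0.30 log units; within the scatter) with neither step beyond the scatter. The combined difference between compound 2 and compound 3 therefore falls to the chloro rather than to the chain.

Going by these compounds, whether a bromo or a methoxy group at this place would keep the lower number stays open, as does the size of the chloro step on the core of compound 1. No measurement here speaks to why the chloro matters in this assay.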